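The compounds below may be only part of what the source reports. "The series", "measured", "known", "first", "only" and "open" are said of these compounds alone.

compound 1 `COCc1cccc2c1CC[C@H]2c1ncc[nH]1` gives 12 mL.min-1.g-1
compound 2 `COCc1c(F)ccc2c1CC[C@H]2c1ncc[nH]1` gives 11 mL.min-1.g-1

In an in vitro ADME assay on microsomes from liver (Homo sapiens) for metabolic stability (on this read-out higher numbers stand for fast clearance and lower numbers for slow clearance), compound 1 and compound 2 lie within the scatter of each other. Compound 3 `c1cc(Cn2cccn2)c2c(c1)[C@H](c1ncc[nH]1)CC2` is not yet measured. It carries 1H-pyrazol-1-yl in place of methoxy on a saturated chain carbon bound to an aromatic carbon. For the measured compounds named here, the only measured step (a 1.1-fold lower number from compound 1 to compound 2 (0.04 log units; within the scatter)) puts fluoro on an aromatic carbon and leaves this group untouched, so it is a weak guide. Going by the values given here, no measured step covers the new group, so no shift beyond the scatter is expected, and the estimated step is a 1.2-fold higher number from compound 1 to compound 3 (0.07 log units; within the scatter) in this assay with wide uncertainty. Compound 3 is estimated at 14 mL.min-1.g-1 (6 mL.min-1.g-1 to 32 mL.min-1.g-1).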

Compound 3, intrinsic clearance in microsomes: 18 mL.min-1.g-1
Compound 3: middle estimate off by 1.3-fold (0.11 log units), on the low side; the measured number falls inside the stated range.
By their numbers in this assay, from the lowest: compounds 2, 1 and 3 (each within the scatter of the next).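

In this assay, putting 1H-pyrazol-1-yl in place of methoxy on a saturated chain carbon bound to an aromatic carbon gives a 1.5-fold higher number from compound 1 to compound 3 (0.18 log units; within the scatter) for this swap. The earlier fluoro step left this position untouched, whereas here a group with a five-membered aromatic ring replaces one with no ring, and the read-out stays within the scatter. No supporting measurement offers a reason for this result.

Still open, from the compounds shown here alone, is whether an amine, a carboxylic acid or a longer chain at this position would also stay within the scatter. Also open, going by these compounds, is how 1H-pyrazol-1-yl and fluoro would behave together on the shared core.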